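Reversed amide link: compound 2 to compound 3

A few compounds are considered here, and "the series" means these few. Any claim that something is new, unique, unknown or untested is made for them only; others in the source may bear on it.

Going by the values given here, in a functional assay on A549 cells (Homo sapiens) for inhibition (on this read-out higher numbers stand for weaker inhibition and lower numbers for stronger inhibition), compound 2 `CC(C)c1cc(-c2n[nH]c(=O)n2-c2cccc(NC(=O)CCCCC(=O)NO)c2)c(O)cc1O` gives 1600 nM and holds the lower of the two numbers so far. Compound 1 `CC(C)c1cc(-c2n[nH]c(=O)n2-c2cccc(C(=O)NCCCCCCC(=O)NO)c2)c(O)cc1O` gives 4600 nM in the same read-out, a gap beyond the scatter. Compound 3 `CC(C)c1cc(-c2n[nH]c(=O)n2-c2cccc(C(=O)NCCCCC(=O)NO)c2)c(O)cc1O` is still unmeasured. It carries (4-(hydroxycarbamoyl)butyl)carbamoyl in place of ((4-(hydroxycarbamoyl)butyl)carbonyl)amino on an aromatic carbon and keeps the same atoms. Among the compounds with values here, no measured pair shows this change, so the forecast is loose. The expected 1.4-fold higher number from compound 2 to compound 3 (0.14 log units; within the scatter) is small and points toward weaker inhibition, possibly within the scatter. The estimate for compound 3 is 2200 nM within a range of 700 nM to 6500 nM for now.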

Compound 3, half-maximal inhibitory concentration: 4600 nM
The estimate for compound 3 lay 2.1-fold (0.32 log units) below the measured number; the range from low to high includes it.
By their numbers in this assay, from the lowest: compound 2; then compounds 1 and 3 (each within the scatter of the next).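

Going by these compounds alone, with the atoms unchanged, the direction of the amide link at this aromatic carbon matters in this assay, giving a 2.9-fold higher number from compound 2 to compound 3 (0.46 log units; beyond the scatter) in the first comparison of this kind. On the carbamoyl side, removing 2-(hydroxycarbamoyl)ethyl in favour of hydroxycarbamoyl on the chain gives no change at the digits printed from compound 1 to compound 3 (within the scatter), so this chain change does not separate the two compounds. Nothing on hand explains the effect of reversing the link.
Still open, going by these compounds, is whether a longer chain on the ((4-(hydroxycarbamoyl)butyl)carbonyl)amino side would be tolerated as well. On these data alone, a carboxylic acid in place of hydroxycarbamoyl also remains untested.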